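The source may hold more compounds than are shown below. What is called first, only, known or untested is meant among the compounds shown, and "the series" means these compounds.

Measured so far in an ADME assay on Vero cells (Chlorocebus sabaeus) for cytotoxicity, read by MTT assay, with a stated time of 48 h; a higher number here means that more compound is tolerated, a lower number that less compound is tolerated:
- compound 1, `O=C(NC(c1ccccc1)C1CC1)c1ccc([N+](=O)[O-])o1`: 22000 nM
- compound 2, `CN(C)c1ccc(C(C)(C)NC(=O)c2ccc([N+](=O)[O-])o2)cc1`: 79000 nM

Compound 2 holds the higher of the two numbers; compound 1 sits well apart from it, beyond the scatter. Compound 3, `CC(C)(NC(=O)c1ccc([N+](=O)[O-])o1)c1ccc(Oc2ccc(Cl)cc2)cc1`, is not yet measured. It differs from compound 2 by 4-chlorophenoxy in place of dimethylamino on an aromatic carbon. Going by the values given here, no single-point step between measured compounds is available, so the size of this change is not anchored. The expectation for compound 3 is a modest move towards the number of compound 1, a 2.3-fold lower number from compound 2 to compound 3 (0.35 log units; beyond the scatter), with a wide range. Compound 3 is estimated at 35000 nM, between 12000 nM and 100000 nM.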

Compound 3, half-maximal cytotoxic concentration: 67000 nM
Compound 3: the middle estimate sits 1.9-fold (0.28 log units) below what was measured; the range from low to high includes it.
By their numbers in this assay, from the lowest: compound 1; then compounds 3 and 2 (each within the scatter of the next).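

In this assay 4-chlorophenoxy in place of dimethylamino, on an aromatic carbon para to a large group, gives a 1.2-fold lower number from compound 2 to compound 3 (0.07 log units; within the scatter) (within the scatter). Going by these compounds alone, this position thus accepts the larger group with its added aromatic ring without a step beyond the scatter, which the earlier compounds could not show. Nothing measured gives a reason for this.

As far as these compounds go, whether a carboxylic acid, a primary amine or a longer alkyl chain at this position would also stay within the scatter remains open. So does whether the 4-chloro substituent on the phenoxy ring matters, as the unsubstituted phenoxy group is not among the compounds shown.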